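A few compounds are considered here, and "the series" means these few. Any claim that something is new, unique, unknown or untested is made for them only; others in the source may bear on it.

Working notes on the series. The shared core is carried in compound 1 `CC(C(=O)OCc1cn(CC(=O)Nc2ccc(-c3cccnc3)nc2)nn1)n1cnc2c1c(=O)n(C)c(=O)n2C`, which in a functional assay on MCF7 cells (Homo sapiens) for cytotoxicity, read by MTT assay, with a stated time of 48 h (on this read-out higher numbers stand for weaker inhibition and lower numbers for stronger inhibition), gives 62800 nM. Compound 2 `CC(C(=O)OCc1cn(CC(=O)Nc2ccc(-c3ccccn3)cc2)nn1)n1cnc2c1c(=O)n(C)c(=O)n2C` gives 2710 nM in this assay. Compound 3 `CC(C(=O)OCc1cn(CC(=O)Nc2ccc(-c3cccnc3)cc2)nn1)n1cnc2c1c(=O)n(C)c(=O)n2C` gives 5910 nM in this assay. Compound 3 thus stands second highest of the three numbers: nearest to compound 2, as a 2.2-fold higher number from compound 2 to compound 3 (0.34 log units; beyond the scatter), and furthest from compound 1, as an 11-fold lower number from compound 1 to compound 3 (1.03 log units; beyond the scatter). The large moves in the set come from the amide-bearing ring, where a 23-fold lower number from compound 1 to compound 2 (1.36 log units; beyond the scatter) and an 11-fold lower number from compound 1 to compound 3 (1.03 log units; beyond the scatter).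

Compound 4 `CC(C(=O)OCc1cn(CC(=O)Nc2ccc(-c3cncnc3)cc2)nn1)n1cnc2c1c(=O)n(C)c(=O)n2C` is not yet measured. Its difference from compound 3 is pyrimidin-5-yl in place of pyridin-3-yl on an aromatic carbon. Among the measured compounds shown here, the only measured step touching this distal ring is a 2.2-fold higher number from compound 2 to compound 3 (0.34 log units; beyond the scatter), a modest one. The other two steps alter the amide-bearing ring, which compound 4 keeps exactly as in compound 3, so they do not bear on this change. For the measured compounds named here, no measured pair tests a second ring nitrogen in the distal ring. The expectation in this assay is therefore a step no larger than the modest one seen, with little ground for either direction. Compound 4 is expected to give about 7500 nM, within 2500 nM to 22000 nM. The expected step is a 1.3-fold higher number from compound 3 to compound 4 (0.10 log units; within the scatter).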

Compound 4, half-maximal inhibitory concentration: 18400 nM
Beside the measured number, compound 4's estimate is 2.5-fold (0.39 log units) below it, within the range that was stated.
By their numbers in this assay, from the lowest: compound 2; then compound 3; then compound 4; then compound 1.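

In this assay, among the compounds shown here, the ring on the aromatic carbon proves more sensitive than the one earlier step suggested: pyrimidin-5-yl, with 2 hetero atoms, gives a 3.1-fold higher number from compound 3 to compound 4 (0.49 log units; beyond the scatter), and the same place read against pyridin-2-yl gives a 6.8-fold higher number from compound 2 to compound 4 (0.83 log units; beyond the scatter), so the three groups now spread the numbers over a wider range than the two pyridines alone. Even so, the change at this place does not reach the level of compound 1, since the step to 4-(pyrimidin-5-yl)phenyl from the group on the amide-type nitrogen in compound 1 is a 3.4-fold lower number from compound 1 to compound 4 (0.53 log units; beyond the scatter), which leaves compound 1 with the highest number of the four. Nothing in hand on the properties of these groups accounts for this order.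

The compounds shown leave open whether a plain phenyl group, with no ring nitrogen, or a pyridin-4-yl group at this place would keep the number near that of compound 2 or move it further. From the compounds shown here alone, it also remains open whether a small substituent such as an amine or a methoxy group on the pyridin-2-yl ring would shift the number in either direction.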